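Removing One Methyl From a Series Without Measurable Potency

The source may report more compounds than this note shows. Statements on the series, on what has been measured and on what is new or still open speak of the compounds shown alone.

Compound 3 `COc1cc(/C=C/C(=O)OCCCCCO[N+](=O)[O-])ccc1OCCCCCO[N+](=O)[O-]` was tested in a functional assay on NCI-H157 cells (Homo sapiens) for cytotoxicity, read by resazurin assay, with a stated time of 72 h; on this read-out higher numbers stand for weaker inhibition and lower numbers for stronger inhibition. For compound 3 the assay returned only a limit, > 50000 nM. Compound 1 `O=C(/C=C/c1ccc(OCCCCCO[N+](=O)[O-])c(O)c1)OCCCCCO[N+](=O)[O-]` differs from it by hydrogen in place of methyl on an oxygen on an aromatic ring. For compound 1 the assay again returned only a limit, > 50000 nM. Both values being limits, the step that the two limits leave unreadable from compound 3 to compound 1 cannot be sized, and this rests on (the limit of > 50000 nM in this assay, at which 3 of the 3 values shown sit). Compound 2 `COc1cc(/C=C/C(=O)OCCCO[N+](=O)[O-])ccc1OCCCO[N+](=O)[O-]` belongs to the same group; the difference between the core of compound 2 and the core of compound 3 is not broken down here. In this assay compound 2 likewise gives only a limit, > 50000 nM. Among the measured compounds shown here, compound 4 `O=C(/C=C/c1ccc(OCCCO[N+](=O)[O-])c(O)c1)OCCCO[N+](=O)[O-]` has not yet been measured and differs from compound 2 by hydrogen in place of methyl on an oxygen on an aromatic ring, the same change as the one from compound 3 to compound 1, at the same place. Because every measured value sits at the limit of > 50000 nM in this assay, at which 3 of the 3 values shown sit, the expected step is a step that the limit leaves unreadable from compound 2 to compound 4, one the limit would again hide. Compound 4 is therefore estimated to come out near 70000 nM, most probably reported once more as a limit rather than a number.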

Compound 4, half-maximal inhibitory concentration: 5710 nM
Compound 4: middle estimate off by 12-fold (1.09 log units), on the high side; measured number below the stated range.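

In this assay, putting hydrogen in place of methyl on the oxygen on the aromatic ring gives an at least 8.7-fold lower number from compound 2 to compound 4 (0.94 log units; beyond the scatter), a step beyond the scatter and the one readable effect of this change in the series. On the core of compound 3, the same methoxy to hydroxy change is carried by compound 1, which gives only a limit, > 50000 nM. The step from compound 2 to compound 4 therefore shows that the change can matter on one core, but it does not show how large the step truly is or whether the same step occurs on the other core, because the starting values are limits rather than numbers: the limit of > 50000 nM in this assay, at which 3 of the 4 values shown sit.

The compounds shown leave open how an amine or a carboxylic acid would read in place of the hydroxy group. They also leave open whether a chain longer than that of compound 3 would bring the hydroxy compound of that core to a measurable number.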